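This account rests on a few compounds, and the source may have more. Where it says the series, first, only, none or still open, it means among the compounds named here.

In a functional assay on DLA cells (Mus musculus) for cytotoxicity, read by LDH release, with a stated time of 48 h (a higher number here means a weaker inhibitor, a lower number a stronger inhibitor), compound 3 (`Cc1cc(C(=O)c2cccc(Br)c2)ccc1OCC(=O)Nc1nc(-c2ccccc2)cs1`) gives 23600 nM. That lies within the scatter of compound 1 (`COc1ccc(-c2csc(NC(=O)COc3ccc(C(=O)c4ccc(C)cc4)cc3C)n2)cc1`) at 18700 nM, while compound 2 (`COc1ccc(-c2csc(NC(=O)COc3ccc(C(=O)c4ccc(F)cc4)cc3C)n2)cc1`) at 5500 nM gives a lower number, beyond the scatter. Compound 4 (`COc1ccc(-c2csc(NC(=O)COc3ccc(C(=O)c4cccc(Br)c4)cc3C)n2)cc1`) differs from compound 3 in one place: methoxy in place of hydrogen on an aromatic carbon, or phenyl to 4-methoxyphenyl. For the measured compounds named here, no measured pair isolates this change. Going by the values given here, the only measured step, a 3.4-fold lower number from compound 1 to compound 2 (0.53 log units; beyond the scatter), is fluoro in place of methyl on an aromatic carbon, and both its compounds already carry the methoxy, so it offers only a rough size for one small swap. A small move toward a lower number is expected, perhaps none beyond the scatter. The expected change is a 1.6-fold lower number from compound 3 to compound 4 (0.20 log units; within the scatter). For compound 4 the estimated value is 15000 nM, with an expected range of 6000 nM to 32000 nM.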

Compound 4, half-maximal inhibitory concentration: 37100 nM
Compound 4: middle estimate off by 2.5-fold (0.39 log units), on the low side, and the stated range ends below it.
By their numbers in this assay, from the lowest: compound 2; then compounds 1, 3 and 4 (each within the scatter of the next).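

In this assay the methoxy, para to a large group, brings a 1.6-fold higher number from compound 3 to compound 4 (0.20 log units; within the scatter) so with a 3-bromophenyl on the carbonyl this change shows no effect beyond the scatter. The group on the carbonyl counts for more here: moving to 3-bromophenyl brings a 6.7-fold higher number from compound 2 to compound 4 (0.83 log units; beyond the scatter) from 4-fluorophenyl but only a 2.0-fold higher number from compound 1 to compound 4 (0.30 log units; within the scatter) from 4-methylphenyl, so among these methoxy compounds 4-fluorophenyl alone stands apart. Going by these compounds, whether a hydroxy group or an amine at the methoxy position would read differently stays open, as does the methoxy step with 4-fluorophenyl on the carbonyl. No measurement shown here accounts for these steps.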